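This account rests on a few compounds, and the source may have more. Where it says the series, first, only, none or still open, it means among the compounds named here.

- compound 1 `CC(=O)Nc1ccc(CN2CCC=C(CCC(=O)NO)C2=O)cc1`: "not determined" (no result reported)
- compound 2 `O=C(CCC1=CCCN(CCCc2ccc(-c3ccccc3)cc2)C1=O)NO`: 3190 nM
- compound 3 `O=C(CCC1=CCCN(CCCCc2cccc3ccccc23)C1=O)NO`: 1670 nM

In a functional assay on HCT-15 cells (Homo sapiens) for inhibition, read by sulforhodamine B assay (on this read-out higher numbers stand for weaker inhibition of growth and lower numbers for stronger inhibition of growth), compound 1 stands at "not determined" (no result reported), so it offers no number to start from. Among the measured compounds shown here, the only numbers come from compound 2 at 3190 nM and compound 3 at 1670 nM, and these two lie within the usual scatter of each other.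

The step to compound 4 `O=C(CCC1=CCCN(Cc2ccc(Br)cc2)C1=O)NO` keeps the shared core and puts bromo in place of acetamido on an aromatic carbon, para to a large group: bromo in place of acetamido on an aromatic carbon. For the measured compounds named here, no measured pair shows what this exchange does, and the missing result for compound 1 means that no step can be counted from it. In this assay, no step beyond the scatter is expected, in either direction, so the expectation for compound 4 rests on the values of compound 2 at 3190 nM and compound 3 at 1670 nM. The range is kept wide for that reason.

Compound 4 is estimated at 2500 nM, with an expected range of 800 nM to 8000 nM.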

Compound 4, concentration for 50% growth inhibition: 1720 nM
Compound 4: middle estimate off by 1.5-fold (0.16 log units), on the high side; the measured number falls inside the stated range.
By their numbers in this assay, from the lowest: compounds 3, 4 and 2 (each within the scatter of the next).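

Among the compounds shown here, no new step can be read from compound 4 in this assay, since no compound with a number differs from it in one place. The compounds shown leave open what bromo in place of acetamido does to growth inhibition. Nothing at hand accounts for the value of compound 4.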